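This account rests on a few compounds, and the source may have more. Where it says the series, first, only, none or still open, it means among the compounds named here.

Measured so far in a functional assay on A549 cells (Homo sapiens) for antiproliferative activity, read by MTT assay, with a stated time of 72 h; on this read-out lower numbers stand for stronger inhibition and higher numbers for weaker inhibition:

Compound 1 `CC(Nc1ncnc2ccc(-c3cnn(C4CCNCC4)c3)cc12)c1c(Cl)ccc(F)c1Cl` gives 7000 nM.
Compound 2 `CC(Nc1nc(N)nc2ccc(-c3cnn(C4CCNCC4)c3)cc12)c1c(Cl)ccc(F)c1Cl` gives 8800 nM.
Compound 3 `Cn1cc(-c2ccc3ncnc(Oc4ccc5ncccc5c4)c3c2)cn1` gives 26600 nM.

Compound 1 holds the lowest of the three numbers. Its nearest neighbour is compound 2, with a 1.3-fold higher number from compound 1 to compound 2 (0.10 log units; within the scatter); compound 3 lies furthest off, beyond the scatter. Compound 4 `c1cnc2ccc(Nc3ncnc4ccc(-c5cnn(C6CCNCC6)c5)cc34)cc2c1` is not yet measured. It differs from compound 1 by quinolin-6-yl in place of 1-(2,6-dichloro-3-fluorophenyl)ethyl on a nitrogen on an aromatic ring. Among the measured compounds shown here, no measured step covers this change: the single step on record, a 1.3-fold higher number from compound 1 to compound 2 (0.10 log units; within the scatter), touches another place. Compound 3 carries the quinolin-6-yl group, but on an oxygen and with a different pyrazole substituent, so its number bears only loosely on compound 4. A higher number is therefore expected for compound 4, estimated at 15000 nM with a range of 5000 nM to 50000 nM, a step of a 2.1-fold higher number from compound 1 to compound 4 (0.33 log units; beyond the scatter).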

Compound 4, half-maximal inhibitory concentration: 32000 nM
The estimate for compound 4 lay 2.1-fold (0.33 log units) below the measured number; the range from low to high includes it.
By their numbers in this assay, from the lowest: compounds 1 and 2 (each within the scatter of the next); then compounds 3 and 4 (each within the scatter of the next).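

Among the compounds shown here, at the nitrogen on an aromatic ring, quinolin-6-yl in place of 1-(2,6-dichloro-3-fluorophenyl)ethyl gives in this assay a 4.6-fold higher number from compound 1 to compound 4 (0.66 log units; beyond the scatter) and so provides the first step beyond the scatter among the compounds that differ in one place. For the compounds shown here, the only earlier such step, at another place, stayed within the scatter. No evidence at hand accounts for this step.

The compounds shown leave open whether a plain benzyl or 1-phenylethyl group on that nitrogen, carrying neither chlorine nor fluorine, would give a number nearer that of compound 1 or compound 4.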